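This account rests on a few compounds, and the source may have more. Where it says the series, first, only, none or still open, it means among the compounds named here.

Series notes, alkoxy variation on the shared core.

Compound 2 `CCOc1ccc2c(Cl)ccnc2c1` is the reference point. In a functional assay on SK-OV-3 cells (Homo sapiens) for cytotoxicity, read by MTT assay, with a stated time of 48 h (a lower number here means a stronger inhibitor, a higher number a weaker inhibitor), compound 2 gives 3460 nM, the lowest of the two numbers recorded so far. Among the compounds with values here, the only other measured member is compound 1 `CCCCOc1ccc2c(Cl)ccnc2c1`, which in this assay gives 4130 nM. The step of a 1.2-fold lower number from compound 1 to compound 2 (0.08 log units; within the scatter) is within the scatter, so the two compounds are not distinguishable on these numbers; neither can be called the stronger inhibitor.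

The next member is compound 3 `CC(C)Oc1ccc2c(Cl)ccnc2c1`. Relative to compound 2 the change is methyl in place of hydrogen on a saturated chain carbon bound to an oxygen on an aromatic ring and a saturated chain carbon, so that the ethoxy of compound 2 becomes isopropoxy.

Within the data shown here, the only measured step that bears on this is the chain-length change from compound 1 to compound 2 on the same alkoxy group, and that step a 1.2-fold lower number from compound 1 to compound 2 (0.08 log units; within the scatter) was within the scatter. With no evidence that adding or removing carbon on this chain moves the number, the expectation for compound 3 in this assay is a step of a 1.0-fold higher number from compound 2 to compound 3 (0.00 log units; within the scatter), not beyond the scatter. The estimate for compound 3 is therefore 3500 nM, with a range of 1800 nM to 7000 nM.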

Compound 3, half-maximal inhibitory concentration: 3060 nM
Compound 3: the middle estimate sits 1.1-fold (0.06 log units) above what was measured, within the range that was stated.
By their numbers in this assay, from the lowest: compounds 3, 2 and 1 (each within the scatter of the next).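

In this assay, within the data shown here, the earlier pair spoke only to chain length, whereas methyl in place of hydrogen on a saturated chain carbon bound to an oxygen on an aromatic ring gives the first reading at that carbon itself, ethyl to isopropyl on the oxygen, with a 1.1-fold lower number from compound 2 to compound 3 (0.05 log units; within the scatter). Isopropyl in place of butyl on an oxygen on an aromatic ring gives a 1.3-fold lower number from compound 1 to compound 3 (0.13 log units; within the scatter), so the ethoxy, butoxy and isopropoxy members cannot be told apart on these numbers, and no order among them can be claimed. No other data accompany these values that would help interpret them.

On these data alone, whether a longer chain than butyl, or an amine or a carboxylic acid carried on the alkoxy chain, would give a step beyond the scatter remains open. All three compounds also share one core, so these numbers do not show whether the same alkoxy changes would read alike on a different core.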